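Methyl for methylamino on the ethynyl compound

The compounds below may be only part of what the source reports. "The series", "measured", "known", "first", "only" and "open" are said of these compounds alone.

In a functional assay on HepG2 cells (Homo sapiens) for antiproliferative activity, read by XTT assay, with a stated time of 72 h (a higher number here means a weaker inhibitor, a lower number a stronger inhibitor), compound 3 (`C#Cc1cn([C@@H]2O[C@H](CO)[C@@H](O)[C@H]2O)c2ncnc(NC)c12`) gives > 15000 nM as a limit, not a number. Compound 1 (`CNc1ncnc2c1c(-c1cccs1)cn2[C@@H]1O[C@H](CO)[C@@H](O)[C@H]1O`) gives > 20000 nM as a limit too. Compound 2 (`CNc1ncnc2c1c(-c1cc3ccccc3o1)cn2[C@@H]1O[C@H](CO)[C@@H](O)[C@H]1O`) gives > 20000 nM as a limit as well. No ranking of compound 3 can be read from these.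

Compound 4 (`C#Cc1cn([C@@H]2O[C@H](CO)[C@@H](O)[C@H]2O)c2ncnc(C)c12`) has methyl in place of methylamino on an aromatic carbon. Three steps are measured: a step that the two limits leave unreadable from compound 1 to compound 2 and a step that the two limits leave unreadable from compound 1 to compound 3 and a step that the two limits leave unreadable from compound 2 to compound 3 all change another group and give no readable size. A modest gain in this assay is tentatively expected, with wide uncertainty. Compound 4 is estimated at 8000 nM within an expected range of 500 nM to 30000 nM as a rough guess. The expected change is an at least 1.8-fold lower number from compound 3 to compound 4 (0.27 log units; that floor lies within the scatter) on this estimate.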

Compound 4, half-maximal inhibitory concentration: 290 nM
Estimate against measurement, compound 4: 28-fold (1.44 log units) above, and the stated range ends above it.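

In this assay, methyl in place of methylamino on the shared core, with ethynyl kept, gives an at least 51-fold lower number from compound 3 to compound 4 (1.71 log units; beyond the scatter), so this place alone can decide whether the ethynyl series shows a measurable value. For the compounds shown here, the steps among compound 1, compound 2 and compound 3 cannot be read, which leaves this as the only readable step. Its size is a floor, because compound 3 stands only at a limit: the limit of > 15000 nM in this assay, at which 1 of the 4 values shown sits.

Open, from the compounds shown here alone, is whether methyl brings a similar step with thiophen-2-yl or 1-benzofuran-2-yl in place of ethynyl. Also open, going by these compounds, is how an ethyl group, a plain amine or a chlorine at this place would compare.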